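The source may report more compounds than this note shows. Statements on the series, on what has been measured and on what is new or still open speak of the compounds shown alone.

Measured in a functional assay on HeLa cells (Homo sapiens) for inhibition, read by MTT assay, with a stated time of 72 h; on this read-out lower numbers stand for stronger inhibition and higher numbers for weaker inhibition:
- Compound 1 `COc1cc(/C=C/C(=O)c2c(OC)cc(O)c(CC=C(C)C)c2O)ccc1O`: 33800 nM
- Compound 2 `COc1ccc(/C=C/C(=O)c2c(OC)cc(O)c(CC=C(C)C)c2O)cc1OC`: 27700 nM
- Compound 3 `COc1cc(OC)c(OC)cc1/C=C/C(=O)c1c(OC)cc(O)c(CC=C(C)C)c1O`: > 50000 nM (a limit)

Compound 2 gives 27700 nM and stands level with compound 1 within the scatter, as a 1.2-fold lower number from compound 1 to compound 2 (0.09 log units; within the scatter) shows. Compound 3 has no number, only a limit, and the limit of > 50000 nM in this assay, at which 1 of the 3 values shown sits, marks that boundary.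

Compound 4 `COc1cc(/C=C/C(=O)c2c(OC)cc(O)c(CC=C(C)C)c2O)cc(OC)c1OC` differs from compound 2 by a single change: methoxy in place of hydrogen on an aromatic carbon. Going by the values given here, the closest precedent is an at least 1.8-fold higher number from compound 2 to compound 3 (0.25 log units; that floor lies within the scatter), the same kind of change made at a different place on the ring. On these data alone, that step is only a floor, so its true size is unknown, and it points towards a higher number. The other measured step, a 1.2-fold lower number from compound 1 to compound 2 (0.09 log units; within the scatter), is a different kind of change and moved the number by no more than the scatter. Together, these two steps suggest a small shift towards a higher number in this assay, probably none beyond the scatter, with some chance that compound 4 also reaches the limit. The expected change is a 1.2-fold higher number from compound 2 to compound 4 (0.08 log units; within the scatter). For compound 4 the estimated value is 33000 nM, with an expected range from 15000 nM to 60000 nM.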

Compound 4, half-maximal inhibitory concentration: > 50000 nM
Compound 4: only a limit was reported; the forecaster's own chance of this, stated with the estimate: 25%; middle value at least 1.5-fold (0.18 log units) from the limit.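

In this assay compound 4 also has no number, only a limit: > 50000 nM. The step reads an at least 1.8-fold higher number from compound 2 to compound 4 (0.25 log units; that floor lies within the scatter), so this methoxy, on an aromatic carbon ortho to a methoxy group and meta to a large group, gives a floor and not a size, and that floor alone does not establish a change beyond the scatter. What the earlier compounds did not show is that methoxy in place of hydrogen at a second place on the ring also ends at this boundary, with compound 3 and compound 4 both sitting there, so neither step from compound 2 has a true size that can be read: the limit of > 50000 nM in this assay, at which 2 of the 4 values shown sit.

On these data alone, how far past this limit compound 3 and compound 4 truly lie stays open, and with it how much this position responds to the change. Also open, as far as these compounds go, is what an amine, a carboxylic acid, a single fluorine atom or a longer chain such as ethoxy would do on this same aromatic carbon in place of methoxy.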